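Swapping a cyanophenyl for a methylpyridinyl on the ethylene

The source may hold more compounds than are shown below. What is called first, only, known or untested is meant among the compounds shown, and "the series" means these compounds.

Measured so far:
Compound 1 `CC/C(=C(/c1ccc(/C=C/C(=O)O)cc1)c1cccc2[nH]ncc12)c1ccccc1`: 21 nM
Compound 2 `CC/C(=C(/c1ccc(/C=C/C(=O)O)cc1)c1ccc2[nH]ncc2c1)c1ccccc1C#N`: 12 nM

In a functional assay on MCF7 cells (Homo sapiens) for cytotoxicity, read by CellTiter-Glo, with a stated time of 5 days (on this read-out higher numbers stand for weaker inhibition and lower numbers for stronger inhibition), compound 2 gives 12 nM. Of the two numbers this is the smaller, but compound 1 sits within the usual scatter of it, so the two cannot be told apart. Compound 3 `CC/C(=C(/c1ccc(/C=C/C(=O)O)cc1)c1ccc2[nH]ncc2c1)c1cnccc1C` differs from compound 2 in one place: 4-methylpyridin-3-yl in place of 2-cyanophenyl on a double-bonded chain carbon bound to a double-bonded chain carbon and a saturated chain carbon. Among the compounds with values here, no step between measured compounds shows how this assay answers such a change, so a step near the scatter is expected, with no clear direction. For compound 3 an estimate of 15 nM is expected, between 5 nM and 45 nM, meaning a step of a 1.3-fold higher number from compound 2 to compound 3 (0.10 log units; within the scatter).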

Compound 3, half-maximal inhibitory concentration: 150 nM
The estimate for compound 3 lay 10-fold (1.00 log units) below the measured number; measured number outside the range, above it.
By their numbers in this assay, from the lowest: compounds 2 and 1 (each within the scatter of the next); then compound 3.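

In this assay, the group on this double-bonded chain carbon clearly matters: 4-methylpyridin-3-yl in place of 2-cyanophenyl gives a 13-fold higher number from compound 2 to compound 3 (1.10 log units; beyond the scatter). The two groups match in hydrogen-bond donors, hydrogen-bond acceptors and net charge, yet their numbers stand far apart. No measurement shown gives a reason for this step.

The compounds shown leave open which part of the change carries the step: the ring nitrogen, the methyl or the loss of the nitrile. A 2-methylphenyl or an unmethylated pyridin-3-yl on this carbon would help separate them.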